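Swapping the aryl on the triazole in a spiro-oxindole series

The compounds below may be only part of what the source reports. "The series", "measured", "known", "first", "only" and "open" are said of these compounds alone.

Compound 2 `Cc1ccccc1-n1nncc1CN1C(=O)C2(C(C#N)=C(N)Oc3c(N)cc4nc5ccccc5nc4c32)c2ccccc21` was examined in an ADME assay on HUVEC cells (Homo sapiens) for antiproliferative activity, read by MTT assay, with a stated time of 48 h; a higher number here means a weaker inhibitor, a lower number a stronger inhibitor. In this assay compound 2 gives > 50000 nM, which is a limit of the assay rather than a number. Compound 1 `N#CC1=C(N)Oc2c(c3nc4ccccc4nc3c3ccccc23)C12C(=O)N(Cc1cnnn1-c1cc(Cl)ccc1Cl)c1ccccc12` was tested alongside it. In this assay compound 1 likewise gives > 50000 nM, again a limit of the assay. Compound 2 therefore stands at the edge of what the assay resolves, and the limit of > 50000 nM in this assay, at which 2 of the 2 values shown sit, shows that it shares that position with every value recorded so far.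

Compound 3 `N#CC1=C(N)Oc2c(N)cc3nc4ccccc4nc3c2C12C(=O)N(Cc1cnnn1-c1ccc(F)cc1)c1ccccc12` has not yet been measured in this assay. It differs from compound 2 in one place: 4-fluorophenyl in place of 2-methylphenyl on an aromatic nitrogen. Among the measured compounds shown here, both values in hand are limits, so no step between measured compounds is available to size this change. The expectation for compound 3 is that the change produces nothing beyond the scatter, with the value most likely remaining at the limit. Compound 3 is expected to give 80000 nM, within a range from 30000 nM to 300000 nM. The estimated step that the limit leaves unreadable from compound 2 to compound 3 is expected to be no step beyond the scatter.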

Compound 3, half-maximal inhibitory concentration: > 50000 nM
Compound 3 was reported as a limit; the forecaster's own chance of this, stated with the estimate: 80%; the middle value does not contradict the limit.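

In this assay compound 3 gives > 50000 nM, which is again a limit of the assay, so no step from compound 2 to compound 3 can be read: the limit of > 50000 nM in this assay, at which 3 of the 3 values shown sit.

The compounds shown leave open whether 4-fluorophenyl in place of 2-methylphenyl on an aromatic nitrogen changes the half-maximal inhibitory concentration at all, and what actual number any of compound 1, compound 2 or compound 3 would give.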